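Trimming two methyl groups from the oxane of compound 2

A few compounds are considered here, and "the series" means these few. Any claim that something is new, unique, unknown or untested is made for them only; others in the source may bear on it.

Compound 1 `COc1ccccc1-n1nc([C@H]2C[C@@H](C)O[C@@H](C)C2)cc1-c1ccc(Cl)cc1`: 91 nM
Compound 2 `COc1ccccc1-n1nc(C2CC(C)(C)OC(C)(C)C2)cc1-c1ccc(Cl)cc1`: 24 nM

In an assay on HEK293 cells for inhibition of Voltage-dependent N-type calcium channel subunit alpha-1B (Homo sapiens), read by patch clamp, using a membrane potential dye (a lower number here means a stronger inhibitor, a higher number a weaker inhibitor), compound 2 gives 24 nM, the lowest of the two numbers; compound 1 gives 91 nM. Among the compounds with values here, the one measured step, a 3.8-fold lower number from compound 1 to compound 2 (0.58 log units; beyond the scatter), added two methyl groups to the oxane and lowered the number beyond the scatter. Compound 3 `COc1ccccc1-n1nc(C2CCOC(C)(C)C2)cc1-c1ccc(Cl)cc1` differs from compound 2 by 2,2-dimethyloxan-4-yl in place of 2,2,6,6-tetramethyloxan-4-yl on an aromatic carbon, removing two methyl groups again. Within the data shown here, that single step is the only guide, and it points the opposite way. Compound 3 is therefore expected to show a step of a 2.1-fold higher number from compound 2 to compound 3 (0.32 log units; beyond the scatter) in this assay, landing near compound 1. The estimate for compound 3 is 50 nM, within 20 nM to 130 nM.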

Compound 3, half-maximal inhibitory concentration: 150 nM
The estimate for compound 3 lay 3.0-fold (0.48 log units) below the measured number, outside the stated range (above it).
By their numbers in this assay, from the lowest: compound 2; then compounds 1 and 3 (each within the scatter of the next).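

In this assay, removing two methyl groups from 2,2,6,6-tetramethyloxan-4-yl gave a 6.3-fold higher number from compound 2 to compound 3 (0.80 log units; beyond the scatter), so among these compounds the lowest number goes with all four methyl groups and is not kept with two. Where the two methyl groups sit made no clear difference: 2,2-dimethyloxan-4-yl in place of 2,6-dimethyloxan-4-yl gave a 1.6-fold higher number from compound 1 to compound 3 (0.22 log units; within the scatter), a step within the scatter. Nothing available explains either step. Still open, on these data alone, is how an unsubstituted oxan-4-yl, a cyclohexyl or a 2,2,6,6-tetramethylpiperidin-4-yl group would compare with the 2,2,6,6-tetramethyloxan-4-yl of compound 2 at this place.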